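The source may hold more compounds than are shown below. What is called first, only, known or untested is meant among the compounds shown, and "the series" means these compounds.

Measured compounds:
compound 1 `Nc1scc(CN2CCN(c3ccc(Cl)cc3F)CC2)c1C(=O)c1ccc(Cl)cc1` with -81%
compound 2 `Nc1scc(CN2CCN(c3ccncc3)CC2)c1C(=O)c1ccc(Cl)cc1` with -15%
compound 3 `Nc1scc(CN2CCN(c3cccc(F)c3F)CC2)c1C(=O)c1ccc(Cl)cc1` with -79%

In a functional assay on CHO cells with adenosine receptor A1 (Homo sapiens) as the target, read by cAMP accumulation and immunoassay, with a stated time of 6 min, tested at 10 uM (on this read-out lower numbers stand for a stronger effect and higher numbers for a weaker effect at the one concentration tested), compound 1 stands lowest of the three; compound 3 lies near it, a number 2 percentage points higher from compound 1 to compound 3 (within the scatter), while compound 2 lies far off, a number 66 percentage points higher from compound 1 to compound 2 (beyond the scatter). Compound 4 `Nc1scc(CN2CCN(c3cccc(Cl)c3)CC2)c1C(=O)c1ccc(Cl)cc1` has not yet been measured. It differs from compound 1 as follows: 3-chlorophenyl in place of 4-chloro-2-fluorophenyl on an amine nitrogen in a ring. For the measured compounds named here, the step that bears on this is the one from compound 1 to compound 3, where one halogenated phenyl replaced another and the read-out hardly moved; the large step to the pyridinyl compound 2 concerns a different kind of change. Compound 4 is therefore expected to stay close to compound 1, with a step of a number 9 percentage points higher from compound 1 to compound 4 (within the scatter) or none beyond the scatter. The estimate for compound 4 is -72%, within -90% to -45%.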

Compound 4, a percentage reported as activity, at one concentration (the size of the read-out at that concentration, not a potency): -77%
Compound 4: the middle estimate sits 5 percentage points above what was measured; low and high end bracket the measured number.
By their numbers in this assay, from the lowest: compounds 1, 3 and 4 (each within the scatter of the next); then compound 2.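

In this assay, the 3-chlorophenyl group on the amine nitrogen carries no fluorine, yet compound 4 stays with the other halogenated phenyl compounds: a number 4 percentage points higher from compound 1 to compound 4 (within the scatter) and a number 2 percentage points higher from compound 3 to compound 4 (within the scatter). Fluorine is therefore not needed at this position among these compounds, and pyridin-4-yl remains the only group set apart, with a number 62 percentage points lower from compound 2 to compound 4 (beyond the scatter). No measurement shown explains this difference. The compounds shown leave open whether an unsubstituted phenyl or a pyridin-3-yl group would stay with compound 4 or fall with compound 2.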